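Salicylic acid azole series: thiazolyl isomer prediction

This account rests on a few compounds, and the source may have more. Where it says the series, first, only, none or still open, it means among the compounds named here.

Measured compounds in a functional assay on the whole organism for inhibition, with Rattus norvegicus as the target, read by paw edema; a lower number here means that less compound is needed, a higher number that more compound is needed for the effect:
compound 1 `O=C(O)c1cc(-n2ccnn2)ccc1O` gives 150 mg/kg
compound 2 `O=C(O)c1cc(-c2cscn2)ccc1O` gives 95 mg/kg
compound 3 `O=C(O)c1cc(-c2c[nH]cn2)ccc1O` gives 100 mg/kg

Compound 3 stands second highest of the three numbers in this assay; its nearest neighbour is compound 2, with a 1.1-fold higher number from compound 2 to compound 3 (0.02 log units; within the scatter), and the furthest is compound 1, with a 1.5-fold lower number from compound 1 to compound 3 (0.18 log units; within the scatter). All three compounds lie within the scatter of one another, so no order among them can be claimed.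

Compound 4 `O=C(O)c1cc(-c2nccs2)ccc1O` has not been measured. It differs from compound 3 as follows: 1,3-thiazol-2-yl in place of 1H-imidazol-4-yl on an aromatic carbon. The measured steps that bear on this are exchanges of one five-membered aromatic ring for another on the same aromatic carbon of the shared core: a 1.6-fold lower number from compound 1 to compound 2 (0.20 log units; within the scatter), a 1.5-fold lower number from compound 1 to compound 3 (0.18 log units; within the scatter) and a 1.1-fold higher number from compound 2 to compound 3 (0.02 log units; within the scatter). None of them reached beyond the scatter, and compound 2 already carries a thiazolyl ring at this carbon. The step to compound 4 is therefore expected to stay within the scatter, with no direction: no change at the digits printed from compound 3 to compound 4 (within the scatter). Compound 4 is estimated at 100 mg/kg, in the range 55 mg/kg to 180 mg/kg.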

Compound 4, dose for half-maximal effect: > 250 mg/kg
Compound 4: no number, only a limit; the forecaster's own chance of this, stated with the estimate: 5%; middle value at least 2.5-fold (0.39 log units) from the limit.
By their numbers in this assay, from the lowest: compounds 2, 3 and 1 (each within the scatter of the next). At a limit, above all of these: compound 4.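

Compound 4 has no number in this assay, only a limit of the assay: the limit of > 250 mg/kg in this assay, at which 1 of the 4 values shown sits.

Among these compounds, this is the first exchange of one five-membered aromatic ring for another at this carbon, meta to the carboxy group and para to the hydroxy group, to reach beyond the scatter, with an at least 2.5-fold higher number from compound 3 to compound 4 (0.39 log units; beyond the scatter) and an at least 2.6-fold higher number from compound 2 to compound 4 (0.42 log units; beyond the scatter); the second step keeps the thiazole ring and changes only its point of attachment, so 1,3-thiazol-2-yl and 1,3-thiazol-4-yl are not interchangeable here. Against the 1H-1,2,3-triazol-1-yl ring the result separates nothing, with an at least 1.6-fold higher number from compound 1 to compound 4 (0.22 log units; that floor lies within the scatter).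

Open: how far compound 4 lies past its limit, and what underlies the step. Also open, going by these compounds, is whether 1,3-thiazol-5-yl or an amine at this carbon would fall with compound 2 and compound 3 or with compound 4.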